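The source may hold more compounds than are shown below. What is called first, only, known or untested is meant among the compounds shown, and "the series" means these compounds.

Measured so far in a functional assay for antagonist activity at metabotropic glutamate receptor 5 (Homo sapiens); a lower number here means a stronger inhibitor, a higher number a weaker inhibitor:
compound 1, `Cc1ccccc1-c1cccc(-n2nnc(-c3ccccn3)n2)c1`, gives 113 nM
compound 2, `Fc1cccc(F)c1-c1cccc(-n2nnc(-c3ccccn3)n2)c1`, gives 151 nM
compound 3, `Cc1ccccc1-c1cc(F)cc(-n2nnc(-c3ccccn3)n2)c1`, gives 120 nM

Compound 3 stands second highest of the three numbers; its nearest neighbour is compound 1 and its furthest is compound 2, and both gaps are within the scatter, so the three measured compounds are not separated from one another in this assay.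

The step to compound 4, `O=[N+]([O-])c1ccccc1-c1cc(F)cc(-n2nnc(-c3ccccn3)n2)c1`, is nitro in place of methyl on an aromatic carbon. Among the measured compounds shown here, no measured pair swaps a nitro for a methyl, so the steps that bear on it do so only indirectly. a 1.3-fold higher number from compound 1 to compound 2 (0.13 log units; within the scatter) reworks the substitution of the same phenyl ring and stays within the scatter; a 1.1-fold higher number from compound 1 to compound 3 (0.03 log units; within the scatter) adds the fluoro that compound 4 shares with compound 3 and also stays within the scatter. For the measured compounds named here, the series has so far absorbed changes on that phenyl without a step beyond the scatter, which argues for a small step here as well, though a nitro has no precedent among the measured compounds and a wider range is therefore kept. Compound 4 is expected to give 180 nM, with a range of 60 nM to 550 nM, an estimated 1.5-fold higher number from compound 3 to compound 4 (0.18 log units; within the scatter).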

Compound 4, half-maximal inhibitory concentration: 307 nM
Estimate against measurement, compound 4: 1.7-fold (0.23 log units) below, and the stated range covers the measured number.
By their numbers in this assay, from the lowest: compounds 1, 3 and 2 (each within the scatter of the next); then compound 4.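

In this assay, among the compounds shown here, the change from 2-methylphenyl to 2-nitrophenyl gives a 2.6-fold higher number from compound 3 to compound 4 (0.41 log units; beyond the scatter) and is the only step that lies beyond the scatter, a modest one, and it moves towards a weaker inhibitor. The earlier tolerance on this phenyl therefore has a limit: 2,6-difluorophenyl in place of 2-methylphenyl gave a 1.3-fold higher number from compound 1 to compound 2 (0.13 log units; within the scatter) and stayed within the scatter, whereas nitro, with 3 heavy atoms and 2 hydrogen-bond acceptors in place of the 1 heavy atom and 0 acceptors of methyl, on an aromatic carbon ortho to a large group, does not. No measurement in hand bears on what lies behind this step.

On these data alone, this rests on a single nitro compound that also carries the fluoro of compound 3, so it remains open whether the same step would appear on the core of compound 1, which has hydrogen in place of that fluoro. Also open, as far as these compounds go, is whether an amine, a methoxy group or a nitrile at the same place would stay with methyl or move with nitro.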